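The compounds below may be only part of what the source reports. "The series", "measured", "known", "first", "only" and "open" are said of these compounds alone.

Of the compounds shown here, three have a number so far. Compound 2, `O=C(NCCCCc1ccccc1)c1cccc(C2SCC(=O)N2c2cccc(F)c2)c1`, gives 39% in a functional assay on U2OS cells (Homo sapiens) for inhibition, read by CCK-8 assay, with a stated time of 72 h, tested at 1 uM (a lower number here means less inhibition, a higher number more inhibition at the concentration tested (going by the name of the read-out)), which is the highest of the three numbers. Compound 1, `COc1ccccc1N1C(=O)C(C)SC1c1cccc(C(=O)NCCCCc2ccccc2)c1`, gives 38% in this assay, a number within the scatter of compound 2, so the two cannot be ranked against each other. Going by the values given here, compound 3, `O=C(NCCCCc1ccccc1)c1cccc(C2OCC(=O)N2c2cccc(F)c2)c1`, gives 25% in this assay, and this is the only value clearly lower than that of compound 2, beyond the scatter. Among the compounds with values here, no single-point comparison between measured compounds has been worked out, so the study offers no step to lean on.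

Compound 4, `COc1ccc(N2C(=O)CSC2c2cccc(C(=O)NCCCCc3ccccc3)c2)c(OC)c1`, has not been measured. It differs from compound 2 in one place: 2,4-dimethoxyphenyl in place of 3-fluorophenyl on an amide-type nitrogen in a ring. Compound 1 also carries a methoxy-bearing aryl on the ring nitrogen and gives 38%, a number level with that of compound 2 within the scatter. On this basis the step of a number 4 percentage points lower from compound 2 to compound 4 (within the scatter) is expected to be small, at most a slight decrease, and likely none beyond the scatter. Compound 4 is therefore estimated at 35% in this assay, with a range from 20% to 50%.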

Compound 4, a percentage reported as inhibition, at one concentration (the size of the read-out at that concentration, not a potency): 37%
Compound 4: middle estimate off by 2 percentage points, on the low side; the measured number falls inside the stated range.
By their numbers in this assay, from the lowest: compound 3; then compounds 4, 1 and 2 (each within the scatter of the next).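

In this assay, going by these compounds alone, putting 2,4-dimethoxyphenyl in place of 3-fluorophenyl on the amide-type nitrogen in the ring gives a number 2 percentage points lower from compound 2 to compound 4 (within the scatter), and this is the only single-place comparison so far. It shows that this position, two ring bonds from the ring sulfur, can take an aryl group with more heavy atoms and with hydrogen-bond acceptors, which 3-fluorophenyl lacks, with no difference beyond the scatter at the one concentration tested. Nothing measured here bears on why the two substituents give numbers that cannot be told apart.

The compounds shown carry only substituted phenyl groups at this nitrogen, so they leave open how a benzyl group, a pyridine ring, or a phenyl ring bearing an amine or a carboxylic acid would read in this assay. Since each number is the size of the read-out at a single concentration, they also leave open whether compound 2 and compound 4 would still match across a range of concentrations.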